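The compounds below may be only part of what the source reports. "The series", "measured", "known", "first", "only" and "open" are said of these compounds alone.

Compound 1, `COc1cc2c(cc1N1C[C@@H](C)N(C)[C@@H](C)C1)N(C(=O)Nc1cccc(C(F)(F)F)c1Cl)CC2`, gives 0 in an assay on isolated protein with 5-hydroxytryptamine receptor 1B (Homo sapiens) as the target; on this read-out higher numbers stand for larger maximal responses and lower numbers for smaller maximal responses.
Compound 2, `COc1cc2c(cc1N1CCN(C)CC1)N(C(=O)c1ccc(-c3cccc(C)n3)c3ccccc13)CC2`, gives 0.9 in this assay.
Compound 3, `COc1cc2c(cc1N1C[C@@H](C)N[C@@H](C)C1)N(C(=O)c1ccc(-c3ccc(N4CCCC4=O)nc3C)cc1)CC2`, gives 0 in this assay.

Among these three numbers, compound 1 and compound 3 sit level at the digits shown, together the lowest, and their difference lies within the usual scatter, so nothing separates them. Compound 2 stands furthest from compound 1, a number higher by an amount well beyond the scatter, and is the only one of the three that shows a sizeable maximal response.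

The step now followed runs from compound 1 to compound 4, `COc1cc2c(cc1N1C[C@@H](C)N(C)[C@@H](C)C1)N(C(=O)Nc1cccc(C(F)(F)F)c1F)CC2`, which has not yet been measured in this assay. The change is small: fluoro in place of chloro on an aromatic carbon. Among the compounds with values here, no measured pair in this set shares that same change, so there is no step in hand to lean on; the expectation rests on compound 1 alone, whose 0 shows no response at all. For compound 4 a step of a number 0.050 higher from compound 1 to compound 4 (within the scatter) is expected, that is none beyond the scatter. Compound 4 is therefore estimated at 0.05, with a range from 0 to 0.2.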

Compound 4, intrinsic activity: the largest response reached, as a fraction of the reference agonist's: 0
The estimate for compound 4 lay 0.050 above the measured number; the measured number falls inside the stated range.
By their numbers in this assay, from the lowest: compounds 1, 3 and 4 (each within the scatter of the next); then compound 2.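

In this assay, replacing the chloro of the 2-chloro-3-(trifluoromethyl)phenyl group with fluoro gives no change at the digits printed from compound 1 to compound 4 (within the scatter). At this carbon, ortho to a trifluoromethyl group, the result therefore separates neither halogen from the other, and compound 4 gives 0 just as compound 1 gives 0. Nothing further is available here to explain why the two halogens give matching results.

The compounds shown leave open whether a group that is not a halogen at this carbon, such as a methoxy group, an amine or a plain hydrogen, would produce any maximal response. Compound 2 differs from these compounds in more than one place, so its higher number cannot be tied to any single part of its structure.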